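The source may hold more compounds than are shown below. What is called first, only, known or untested is meant among the compounds shown, and "the series" means these compounds.

Measured compounds:
compound 1 `C[C@@H]1CN(C(=O)C(=O)c2c[nH]c3c(-c4ncco4)ccnc23)CCN1C(=O)c1ccccc1` — 2480 ng.h/mL
compound 2 `C[C@@H]1CN(C(=O)C(=O)c2c[nH]c3c(-c4nccs4)ccnc23)CCN1C(=O)c1ccccc1` — 597 ng.h/mL

Within the data shown here, compound 2, which carries the 1,3-thiazol-2-yl group, has the lower of the two numbers so far in an ADME assay on the whole organism (plasma) for pharmacokinetics, with Rattus norvegicus as the target, at a dose of 5 mg/kg by the oral route; a higher number here means more compound in the circulation at the dose given, a lower number less compound in the circulation; compound 1 sits above it, and the step of a 4.2-fold lower number from compound 1 to compound 2 (0.62 log units; beyond the scatter) lies beyond the scatter. Compound 3 `C[C@@H]1CN(C(=O)C(=O)c2c[nH]c3c(-n4nccn4)ccnc23)CCN1C(=O)c1ccccc1` has not yet been measured in this assay. It differs from compound 2 in one place: 2H-1,2,3-triazol-2-yl in place of 1,3-thiazol-2-yl on an aromatic carbon. Among the measured compounds shown here, the only measured step that bears on this position is a 4.2-fold lower number from compound 1 to compound 2 (0.62 log units; beyond the scatter), in which a five-membered ring with 2 hetero atoms gave way to another with 2 hetero atoms and the number fell. For the measured compounds named here, no step shows a ring with 3 hetero atoms entering at this place, so the direction for compound 3 is not fixed by the data. Since the change leaves the 1,3-thiazol-2-yl group that marks the lower of the two values in this assay, the number for compound 3 is expected to move up by a 1.8-fold higher number from compound 2 to compound 3 (0.27 log units; within the scatter). For compound 3 the estimate is 1100 ng.h/mL, with a range from 350 ng.h/mL to 3500 ng.h/mL.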

Compound 3, area under the concentration-time curve: 1460 ng.h/mL
Estimate against measurement, compound 3: 1.3-fold (0.12 log units) below; low and high end bracket the measured number.
By their numbers in this assay, from the lowest: compound 2; then compounds 3 and 1 (each within the scatter of the next).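

In this assay, the 2H-1,2,3-triazol-2-yl group of compound 3 brings the first ring with 3 hetero atoms to this place, and replacing the 1,3-thiazol-2-yl group gives a 2.4-fold higher number from compound 2 to compound 3 (0.39 log units; beyond the scatter) on this measure. Replacing the 1,3-oxazol-2-yl group with the same ring gives a 1.7-fold lower number from compound 1 to compound 3 (0.23 log units; within the scatter) and stays within the scatter, so compound 2 alone stands apart, and the count of hetero atoms in the ring does not sort the three compounds, since compound 1 with 2 hetero atoms cannot be separated from compound 3 with 3, while compound 2 with 2 lies lower than both. Nothing measured here explains these differences.

The compounds shown leave open whether a larger aromatic ring such as pyridin-2-yl, or a non-aromatic group such as an amine or a carboxylic acid, at this place on the shared core would keep the number near that of compound 1 and compound 3 or take it nearer to that of compound 2. They also leave open whether the same differences among the three rings would hold with another group in place of the benzoyl group.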